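The compounds below may be only part of what the source reports. "The series", "measured", "known", "first", "only" and "open" are said of these compounds alone.

Measured so far in an assay on cells for antagonist activity at transient receptor potential cation channel subfamily V member 1 (Homo sapiens), read by FLIPR and calcium flux, with a stated time of 6 min; on this read-out lower numbers stand for stronger inhibition and higher numbers for weaker inhibition:
compound 1 `CC(C(=O)NCc1ccc(C(C)(C)C)nc1OCc1ccc(F)cc1)c1ccc(NS(C)(=O)=O)c(F)c1` gives 0.8 nM
compound 2 `CC(C(=O)NCc1ccc(C(C)(C)C)nc1SCc1ccccc1)c1ccc(NS(C)(=O)=O)c(F)c1` gives 4 nM

For the measured compounds named here, compound 2 stands at the higher of the two numbers in this assay; its only neighbour is compound 1, and the step of a 5.0-fold higher number from compound 1 to compound 2 (0.70 log units; beyond the scatter) is a modest one that exchanges benzylsulfanyl for (4-fluorobenzyl)oxy on the shared core. Compound 3 `COc1ccc(CSc2nc(C(C)(C)C)ccc2CNC(=O)C(C)c2ccc(NS(C)(=O)=O)c(F)c2)cc1` differs from compound 2 by methoxy in place of hydrogen on an aromatic carbon of the benzyl ring. Going by the values given here, no measured step isolates a change of this kind: the single step known, a 5.0-fold higher number from compound 1 to compound 2 (0.70 log units; beyond the scatter), alters the linking atom and the benzyl substituent at the same time, so it gives no clean reading of what a substituent on that ring does on its own. In the absence of any step that bears on it, the step of no change at the digits printed from compound 2 to compound 3 (within the scatter) is expected to stay within the scatter. Compound 3 is therefore expected to give about 4 nM in this assay, within a range of 1.5 nM to 12 nM.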

Compound 3, inhibition constant: 3.5 nM
Beside the measured number, compound 3's estimate is 1.1-fold (0.06 log units) above it, within the range that was stated.
By their numbers in this assay, from the lowest: compound 1; then compounds 3 and 2 (each within the scatter of the next).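

In this assay, replacing benzylsulfanyl with (4-methoxybenzyl)sulfanyl gives a 1.1-fold lower number from compound 2 to compound 3 (0.06 log units; within the scatter), so the ring place para to a large group accepts a methoxy on this sulfanyl compound with no difference that can be read from hydrogen. Exchanging (4-fluorobenzyl)oxy for (4-methoxybenzyl)sulfanyl gives a 4.4-fold higher number from compound 1 to compound 3 (0.64 log units; beyond the scatter), which lies beyond the scatter just as a 5.0-fold higher number from compound 1 to compound 2 (0.70 log units; beyond the scatter) does, and so compound 1 stands apart from both sulfanyl compounds whether their benzyl ring carries hydrogen or methoxy. Nothing at hand offers an explanation for either of these results.

Whether the linking atom or the substituent on the benzyl ring accounts for the distance between compound 1 and the sulfanyl compounds remains open, and a (4-fluorobenzyl)sulfanyl group would bear directly on that question. Also open, going by these compounds, is what an amine, a carboxylic acid or a longer chain such as butoxy would do at the place that methoxy occupies, as a single methoxy says little about how much that place tolerates.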